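Little Movement Expected at One Chain Carbon

The source may hold more compounds than are shown below. What is called first, only, known or untested is meant among the compounds shown, and "the series" means these compounds.

Compound 1 `CC(C)C(CC1C(=O)NC(=O)N1C)c1ccc(-c2ccc3cccc(F)c3c2)[nH]c1=O` gives 17.6 10^-6 cm/s
Compound 2 `CC(C)C(c1ccc(-c2ccc3cccc(F)c3c2)[nH]c1=O)C1SC(=O)NC1=O` gives 26.3 10^-6 cm/s
Compound 3 `CC(C)C(/C=C1\SC(=O)NC1=O)c1ccc(-c2ccc3cccc(F)c3c2)[nH]c1=O` gives 15.4 10^-6 cm/s

These values come from an ADME assay on MDCK cells (Canis lupus familiaris) for permeability, in the apical to basolateral direction (a lower number here means that the compound crosses the layer more slowly, a higher number that the compound crosses the layer faster), and lie close together. Compound 3 stands within the scatter of both others, with a 1.1-fold lower number from compound 1 to compound 3 (0.06 log units; within the scatter) and a 1.7-fold lower number from compound 2 to compound 3 (0.23 log units; within the scatter) on the way to it. Compound 4 `CC(C)C(CC1NC(=O)NC1=O)c1ccc(-c2ccc3cccc(F)c3c2)[nH]c1=O` has not yet been measured. It differs from compound 3 in one place, a group of 8 heavy atoms (4 carbon, 2 nitrogen, 2 oxygen; one five-membered non-aromatic ring with 2 hetero atoms) in place of a group of 8 heavy atoms (4 carbon, 1 nitrogen, 2 oxygen, 1 sulfur; one five-membered non-aromatic ring with 2 hetero atoms), on a saturated chain carbon bound to an aromatic carbon and a saturated chain carbon and the entering group is (2,5-dioxoimidazolidin-4-yl)methyl. Compound 1 carries (3-methyl-2,5-dioxoimidazolidin-4-yl)methyl at that carbon. The two steps above and a 1.5-fold higher number from compound 1 to compound 2 (0.17 log units; within the scatter) all exchange the group at this carbon, and none exceeds the scatter. For the measured compounds named here, no measured pair isolates the missing methyl, so its contribution remains unknown. In this assay no step beyond the scatter is therefore expected, and the direction is not firmly indicated. The estimate means an expected step of a 1.1-fold lower number from compound 3 to compound 4 (0.04 log units; within the scatter) and stays within the scatter. Compound 4 is expected at 14 10^-6 cm/s within an estimated range of 7 10^-6 cm/s to 24 10^-6 cm/s on this read-out.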

Compound 4, apparent permeability: 17.1 10^-6 cm/s
For compound 4 the middle estimate is 1.2-fold (0.09 log units) below the measured one; low and high end bracket the measured number.
By their numbers in this assay, from the lowest: compounds 3, 4, 1 and 2 (each within the scatter of the next).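

In this assay the methyl can now be read on its own, in a pair that differs only by hydrogen in place of methyl on an amide-type nitrogen in a ring, and the result is a 1.0-fold lower number from compound 1 to compound 4 (0.01 log units; within the scatter). The two other new steps, a 1.1-fold higher number from compound 3 to compound 4 (0.05 log units; within the scatter) and a 1.5-fold lower number from compound 2 to compound 4 (0.19 log units; within the scatter), also stay within the scatter, so all four groups on the saturated chain carbon, with or without the methyl, give values that cannot be told apart here. No evidence is available that explains this outcome.

From the compounds shown here alone, whether an ethyl group on that nitrogen, or an amine or a carboxylic acid on the chain carbon, would move the number beyond the scatter remains open. Going by these compounds, all four compounds carry the same core, so the effect of a change there also remains unknown.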